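This account rests on a few compounds, and the source may have more. Where it says the series, first, only, none or still open, it means among the compounds named here.

- compound 1 `CC(=O)NCCn1c(-c2ccccc2Cl)nc2c(N3CCN(C)CC3)nc(C)nc21`: 0%
- compound 2 `Cc1nc(N2CCN(C)CC2)c2nc(-c3ccccc3Cl)n(CCN3CCCC3=O)c2n1`: 28%
- compound 3 `Cc1nc(N2CCN(C)CC2)c2nc(-c3ccccc3Cl)n(C3CC3)c2n1`: not yet measured

These numbers come from an ADME assay (liver) for metabolic stability, with Liver microsome (Rattus norvegicus) as the target, read by LC-MS, using microsomes, with a stated time of 30 min, tested at 4 uM; on this read-out higher numbers stand for a more stable compound and lower numbers for a less stable compound. Compound 2 stands highest of the two measured compounds, clearly ahead of compound 1. The next change removes the whole chain from compound 2: cyclopropyl in place of 2-(2-oxopyrrolidin-1-yl)ethyl on an aromatic nitrogen. In words, cyclopropyl takes the place of 2-(2-oxopyrrolidin-1-yl)ethyl on an aromatic nitrogen.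

Among the measured compounds shown here, only one measured step bears on this. The modest step of a number 28 percentage points higher from compound 1 to compound 2 (beyond the scatter) lies beyond the scatter and also changes this chain. For the measured compounds named here, it shows that a change here can move the number, but no measured compound carries cyclopropyl, so it gives no direction. The starting point therefore remains compound 2 at 28%.

The expected step is a number 2 percentage points higher from compound 2 to compound 3 (within the scatter), with no firm direction and real uncertainty on both sides. For compound 3 the estimated value is 30%, with an expected range from 8% to 60%.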

Compound 3, percent of the compound remaining: 44%
Compound 3: the middle estimate sits 14 percentage points below what was measured, within the range that was stated.
By their numbers in this assay, from the lowest: compound 1; then compound 2; then compound 3.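

In this assay, the amide-bearing chain on the aromatic nitrogen proves unnecessary for stability: putting cyclopropyl in place of 2-(2-oxopyrrolidin-1-yl)ethyl gives a number 16 percentage points higher from compound 2 to compound 3 (beyond the scatter) and putting it in place of 2-acetamidoethyl gives a number 44 percentage points higher from compound 1 to compound 3 (beyond the scatter) in this comparison. Across these three compounds, the group with the fewest heavy atoms and no hydrogen-bond acceptor therefore stands highest, and none of the three goes against that order. No supporting measurement is available to explain the gain.

Because the swap removes the chain, the amide carbonyl and the five-membered ring together, these compounds cannot show which of those changes matters. Going by these compounds, how a plain ethyl group, a cyclobutyl ring or a chain ending in an amine would behave on this nitrogen also remains open.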